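A Hydroxy Group Added to a Shared Core

This account rests on a few compounds, and the source may have more. Where it says the series, first, only, none or still open, it means among the compounds named here.

Of the compounds shown here, three that share one core have been tested in an in vitro assay on SH-EP1 cells for displacement of a labelled ligand from Neuronal acetylcholine receptor; alpha4/beta2 (Homo sapiens), tested at 5 uM; on this read-out lower numbers stand for less inhibition and higher numbers for more inhibition at the one concentration tested (going by the name of the read-out). Compound 1 `C1=NCC2(CN3CCC2CC3)NC=C1c1ccccc1` gives 6%. In this assay compound 2 `Nc1c(C2=NC3(CN2)CN2CCC3CC2)oc2ccccc12` gives 9%. In this assay compound 3 `c1ccc(C2=NC3(CN2)CN2CCC3CC2)cc1` gives 11%. Where compound 3 stands: its number is separated from that of compound 2 and from that of compound 1 only by amounts that fall within the usual scatter of repeated measurements, so the three compounds cannot be told apart, and each of them displaces little of the labelled ligand at the single concentration tested.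

Compound 4 `Oc1ccccc1C1=NC2(CN1)CN1CCC2CC1` has not yet been measured. It differs from compound 3 in one place: hydroxy in place of hydrogen on an aromatic carbon. Going by the values given here, no measured pair shows the effect of such a change, so the expectation rests on the three numbers alone. The step of a number 1 percentage points higher from compound 3 to compound 4 (within the scatter) is expected to be small, in no set direction and not beyond the scatter. Compound 4 is estimated to give 12% in this assay, within a range from 0% to 30%.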

Compound 4, a percentage reported as inhibition, at one concentration (the size of the read-out at that concentration, not a potency): 4%
Beside the measured number, compound 4's estimate is 8 percentage points above it; low and high end bracket the measured number.
By their numbers in this assay, from the lowest: compounds 4, 1, 2 and 3 (each within the scatter of the next).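

Hydroxy in place of hydrogen on an aromatic carbon, ortho to a large group, gives a number 7 percentage points lower from compound 3 to compound 4 (within the scatter) in this assay. Going by these compounds alone, this is the first pair that differs in one place, and it shows that this single change, which adds one oxygen atom, does not move the number beyond the scatter, so compound 4 cannot be told apart from compound 3. No independent measurement here bears on what lies behind this result.

On these data alone, whether an amine, a methoxy group or a carboxylic acid on the same aromatic carbon would give a step beyond the scatter remains open. Also open, as far as these compounds go, is what hydroxy would do on compound 1, which carries a six-membered aromatic ring of carbon only on a different core.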